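The compounds below may be only part of what the source reports. "The series", "measured", "known", "first", "only" and "open" are said of these compounds alone.

Measured so far in a functional assay on MCF7 cells (Homo sapiens) for antiproliferative activity, read by MTT assay, with a stated time of 48 h; on this read-out lower numbers stand for stronger inhibition and higher numbers for weaker inhibition

- compound 1 `CC(=O)OC/C1=C/C[C@](C)(CCC=C(C)C)/C=C/[C@@H](OC(=O)C=C(C)C)[C@](C)(O)/C=C/C1=O` gives 4510 nM
- compound 2 `CC(C)=CCC[C@]1(C)/C=C/[C@@H](OC(=O)C=C(C)C)[C@](C)(O)/C=C/C(=O)/C(CN2CCCC2)=C\C1` gives 220 nM
- compound 3 `CC(C)=CCC[C@]1(C)/C=C/[C@@H](OC(=O)C=C(C)C)[C@](C)(O)/C=C/C(=O)/C(COC(=O)c2ccc([N+](=O)[O-])cc2)=C\C1` gives 670 nM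

Compound 2 stands lowest of these three, and both of the others lie beyond the scatter from it, so it is the strongest inhibitor among them. Compound 4 `CO/N=C/C1=C/C[C@](C)(CCC=C(C)C)/C=C/[C@@H](OC(=O)C=C(C)C)[C@](C)(O)/C=C/C1=O` differs from it by one change (a group of 4 heavy atoms (2 carbon, 1 nitrogen, 1 oxygen; no ring) in place of a group of 6 heavy atoms (5 carbon, 1 nitrogen; one five-membered non-aromatic ring with 1 hetero atom), on a double-bonded ring carbon) on a double-bonded ring carbon of the shared core. All three measured steps also alter the group on this carbon. Pyrrolidin-1-yl in place of acetoxy was a large step (a 21-fold lower number from compound 1 to compound 2 (1.31 log units; beyond the scatter)). 4-Nitrophenyl in place of methyl was a modest one (a 6.7-fold lower number from compound 1 to compound 3 (0.83 log units; beyond the scatter)), and ((4-nitrophenyl)carbonyl)oxy in place of pyrrolidin-1-yl was also modest (a 3.0-fold higher number from compound 2 to compound 3 (0.48 log units; beyond the scatter)). Compound 4 gives up the pyrrolidin-1-yl, and both measured compounds without that group stand higher than compound 2. For the measured compounds named here, neither carries the group that enters, so no direct precedent exists. In this assay a modest rise is therefore expected, although a large one remains possible. The estimated change is a 4.1-fold higher number from compound 2 to compound 4 (0.61 log units; beyond the scatter) as the expected outcome. For compound 4 the estimate is 900 nM with an expected range from 280 nM to 3500 nM as its ends.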

Compound 4, half-maximal inhibitory concentration: 2510 nM
Beside the measured number, compound 4's estimate is 2.8-fold (0.45 log units) below it; the range from low to high includes it.
By their numbers in this assay, from the lowest: compound 2; then compound 3; then compounds 4 and 1 (each within the scatter of the next).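

In this assay, swapping the (pyrrolidin-1-yl)methyl group for the ringless group of compound 4 at this double-bonded ring carbon gives an 11-fold higher number from compound 2 to compound 4 (1.06 log units; beyond the scatter), a larger loss than the move from compound 2 to compound 3, whereas the change from the acetoxy-bearing parent gives a 1.8-fold lower number from compound 1 to compound 4 (0.25 log units; within the scatter), so the ringless group leaves compound 4 no different from compound 1 on this read-out. Compound 4 also carries a nitrogen in this group, which shows that having a nitrogen here does not by itself bring the number down to that of compound 2. Nothing at hand explains why these two nitrogen-bearing groups differ so widely.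

Still open, as far as these compounds go, is whether the low number of compound 2 depends on the five-membered ring or simply on an amine nitrogen on the saturated chain carbon, a question that a (diethylamino)methyl group, with the same kind of amine but no ring, or a (piperidin-1-yl)methyl group, with a larger ring, could help to settle. The compounds shown also leave open how a carboxylic acid at this carbon would fare.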